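The source may report more compounds than this note shows. Statements on the series, on what has been measured and on what is new or still open speak of the compounds shown alone.

Working notes on the series. The compounds share one core and differ only in the five-membered ring placed on an amide-type nitrogen, and that ring decides the read-out in an assay on HEK293 cells for agonist activity at transient receptor potential cation channel subfamily M member 8 (Homo sapiens), read by fluorescence and calcium flux, with a stated time of 15 min; on this read-out higher numbers stand for an effect only at larger amounts of compound and lower numbers for an effect already at smaller amounts. Compound 1 `Cc1ccc(OCC(=O)N(Cc2cccs2)C2COC2)cc1` gives 23000 nM; compound 2 `Cc1ccc(OCC(=O)N(Cc2cccs2)c2ccnn2C)cc1` gives 422 nM; compound 3 `Cc1ccc(OCC(=O)N(Cc2cccs2)c2ncco2)cc1` gives 0.3 nM. Compound 3 stands lowest of the three numbers, reached by a 1400-fold lower number from compound 2 to compound 3 (3.15 log units; beyond the scatter) and by a 77000-fold lower number from compound 1 to compound 3 (4.88 log units; beyond the scatter), while the remaining measured exchange gave a 55-fold lower number from compound 1 to compound 2 (1.74 log units; beyond the scatter).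

Compound 4 `Cc1ccc(OCC(=O)N(Cc2cccs2)c2cn[nH]c2)cc1` has not been measured in this assay. It differs from compound 3 as follows: 1H-pyrazol-4-yl in place of 1,3-oxazol-2-yl on an amide-type nitrogen. The step that bears most on it is a 1400-fold lower number from compound 2 to compound 3 (3.15 log units; beyond the scatter), which shows that exchanging the 1,3-oxazol-2-yl for another five-membered aromatic ring with two hetero atoms moved the number a long way; compound 4 undoes that exchange in kind, though with a different ring. A large step upward is therefore expected in this assay. For compound 4 the estimate is 300 nM, within 20 nM to 5000 nM, which is expected to mean a 1000-fold higher number from compound 3 to compound 4 (3.00 log units; beyond the scatter).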

Compound 4, half-maximal effective concentration: 1.4 nM
Compound 4: the middle estimate sits 210-fold (2.33 log units) above what was measured, and the stated range ends above it.
By their numbers in this assay, from the lowest: compound 3; then compound 4; then compound 2; then compound 1.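

In this assay, the low number at this position is not confined to 1,3-oxazol-2-yl: a 4.7-fold higher number from compound 3 to compound 4 (0.67 log units; beyond the scatter) is only a modest step, even though 1H-pyrazol-4-yl brings a hydrogen-bond donor where the ring it replaces has none. Sharing the pyrazole name does not settle the result either, given a 300-fold lower number from compound 2 to compound 4 (2.48 log units; beyond the scatter), while a 16000-fold lower number from compound 1 to compound 4 (4.22 log units; beyond the scatter) leaves oxetan-3-yl far from this aromatic ring too. No supporting data bear on why these groups differ.

The compounds shown leave open how much of the gap between 1-methyl-1H-pyrazol-5-yl and 1H-pyrazol-4-yl belongs to the methyl group and how much to the point of attachment. A 1-methyl-1H-pyrazol-4-yl group on the same amide-type nitrogen would separate the two.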